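Trifluoromethyl in place of tert-butyl: working notes

This account rests on a few compounds, and the source may have more. Where it says the series, first, only, none or still open, it means among the compounds named here.

Among the compounds with values here, in a functional assay on A549 cells (Homo sapiens) for cytotoxicity, read by MTT assay, with a stated time of 48 h (a lower number here means a stronger inhibitor, a higher number a weaker inhibitor), compound 1 `CC(C)(C)c1ccc(-c2cnc3c(c2)C=CS(=O)(=O)O3)cc1` gives 149000 nM as the higher of the two numbers measured so far. Compound 2 `O=S1(=O)C=Cc2cc(-c3cc(Cl)cc(Cl)c3)cnc2O1` gives 14000 nM as the lower number, and this gap lies beyond the usual scatter. Compound 3 `O=S1(=O)C=Cc2cc(-c3ccc(C(F)(F)F)cc3)cnc2O1`, not yet measured, carries trifluoromethyl in place of tert-butyl on an aromatic carbon, para to a large group trifluoromethyl in place of tert-butyl on an aromatic carbon in its difference from compound 1. Within the data shown here, no measured pair shows this change alone, so the expectation has little support. With compound 2 at 14000 nM as the only other reference, a move towards a lower number is expected, and the expected size is a 3.7-fold lower number from compound 1 to compound 3 (0.57 log units; beyond the scatter) in this assay as a rough guide. For compound 3 the estimated value is 40000 nM with an expected range from 12000 nM to 150000 nM for the coming measurement.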

Compound 3, half-maximal inhibitory concentration: 77000 nM
Compound 3: the middle estimate sits 1.9-fold (0.28 log units) below what was measured; the range from low to high includes it.
By their numbers in this assay, from the lowest: compound 2; then compounds 3 and 1 (each within the scatter of the next).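

In this assay, within the data shown here, the exchange of tert-butyl for trifluoromethyl on an aromatic carbon, para to a large group, gives a 1.9-fold lower number from compound 1 to compound 3 (0.29 log units; within the scatter) and is the first change that can be read alone. At this position, on the core of compound 1, the two groups therefore cannot be told apart in this read-out, and the single-place data show no sensitivity to this exchange. Nothing available bears on why the two groups read alike.

From the compounds shown here alone, the single-place comparison spans just these two groups, so it remains open whether an amine or a carboxylic acid at the same position would separate from them beyond the scatter. Going by these compounds, whether the same exchange reads alike at another place on the aromatic ring also remains open.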